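Amine substituent changes on the shared core

The source may hold more compounds than are shown below. What is called first, only, known or untested is meant among the compounds shown, and "the series" means these compounds.

compound 1 `CCCCN(CC)Cc1c(C(F)(F)F)nc2n(-c3c(C)cc(C)cc3C)c(Cl)cn12` gives 78 nM in an assay on cells for displacement of a labelled ligand from corticotropin-releasing factor receptor 1 (Homo sapiens), with a stated time of 100 min; on this read-out lower numbers stand for stronger inhibition and higher numbers for weaker inhibition
compound 2 `CCN(CCC1CC1)Cc1c(C(F)(F)F)nc2n(-c3c(C)cc(C)cc3C)c(Cl)cn12` gives 13 nM
compound 3 `Cc1cc(C)c(-n2c(Cl)cn3c(CN(CCC4CC4)CCC(F)(F)F)c(C(F)(F)F)nc23)c(C)c1` gives 110 nM

Compound 3 carries the highest number of the three; its gap to compound 1 lies within the scatter, whereas a 6.0-fold lower number from compound 1 to compound 2 (0.78 log units; beyond the scatter) and an 8.5-fold higher number from compound 2 to compound 3 (0.93 log units; beyond the scatter) both exceed it. Compound 4 `Cc1cc(C)c(-n2c(Cl)cn3c(CN(CCC(F)(F)F)Cc4ccc(F)cc4)c(C(F)(F)F)nc23)c(C)c1` differs from compound 3 by 4-fluorophenyl in place of cyclopropylmethyl on a saturated chain carbon bound to an amine nitrogen. Within the data shown here, both measured steps alter a group two bonds along the chain from the amine nitrogen, and neither swaps a saturated ring for an aromatic one, so no step bears directly on this change. The expectation for compound 4 is therefore a step of a 1.1-fold lower number from compound 3 to compound 4 (0.04 log units; within the scatter) of no clear direction beyond the scatter. Compound 4 is estimated at 100 nM in this assay, with a range from 25 nM to 400 nM.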

Compound 4, inhibition constant: 34 nM
For compound 4 the middle estimate is 2.9-fold (0.47 log units) above the measured one; measured number inside the range.
By their numbers in this assay, from the lowest: compound 2; then compound 4; then compounds 1 and 3 (each within the scatter of the next).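

In this assay, 4-fluorophenyl in place of cyclopropylmethyl on a saturated chain carbon bound to an amine nitrogen gives a 3.2-fold lower number from compound 3 to compound 4 (0.51 log units; beyond the scatter). Among these compounds, the earlier steps changed only saturated groups, so this is the first sign that an aromatic ring is accepted here, with the number moving beyond the scatter. No measurement on hand accounts for the step.

Open, from the compounds shown here alone, is whether benzyl without the fluorine, or a pyridinylmethyl group, would behave like 4-fluorobenzyl. Also open, going by these compounds, is whether 4-fluorobenzyl would give a step of similar size with ethyl on the amine.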